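Carboxyphenyl ether series: acid position on the distal ring

This account rests on a few compounds, and the source may have more. Where it says the series, first, only, none or still open, it means among the compounds named here.

For the measured compounds named here, compound 1 `Cc1c(OCCCCOc2ccc(C(=O)O)cc2F)ccc(C(=O)CC(C)C)c1O` is the only member with a number so far: in an assay on HEK293 cells for positive allosteric modulation of metabotropic glutamate receptor 2 (Rattus norvegicus), read by thallium flux, with a stated time of 2.5 min (on this read-out higher numbers stand for an effect only at larger amounts of compound and lower numbers for an effect already at smaller amounts), compound 1 gives 102 nM. Compound 2 `COC(=O)c1ccc(OCCCCOc2ccc(C(=O)CC(C)C)c(O)c2C)cc1`, the methyl ester, has in this assay only the entry "not determined" (no result reported), so it stands nowhere on the scale and anchors nothing. Compound 3 `Cc1c(OCCCCOc2cccc(C(=O)O)c2)ccc(C(=O)CC(C)C)c1O` differs from compound 2 by 3-carboxyphenyl in place of 4-(methoxycarbonyl)phenyl on an oxygen on a saturated carbon, the ester giving way to a free acid. Going by the values given here, no measured step exists between compound 2 and compound 3, and with compound 2 unmeasured no size or direction for this change can be read from the data; any guess must lean on compound 1, which carries its acid and a fluorine and gives 102 nM in this assay. Compound 3 is expected in this assay at roughly 300 nM, with a plausible range from 80 nM to 1500 nM.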

Compound 3, half-maximal effective concentration: 222 nM
For compound 3 the middle estimate is 1.4-fold (0.13 log units) above the measured one; measured number inside the range.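

In this assay, 3-carboxyphenyl in place of 4-carboxy-2-fluorophenyl on an oxygen on a saturated carbon gives a 2.2-fold higher number from compound 1 to compound 3 (0.34 log units; beyond the scatter), a modest step that shows this place tolerates a change of distal ring while a free acid is kept. The step combines the acid's placement with the loss of fluorine, so the share of each cannot be separated. Nothing available gives a reason for the shift.

For the compounds shown here, no step to or from compound 2 can be read, so the change from methyl ester to free acid remains without a size. Still open, from the compounds shown here alone, are the 4-carboxyphenyl group without fluorine, the 3-carboxyphenyl group with fluorine, and a primary amide or tetrazole in place of the carboxylic acid.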